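The compounds below may be only part of what the source reports. "The series", "measured", "known", "first", "only" and "open" are said of these compounds alone.

Working notes on the series. Of the compounds shown here, two have numbers so far in a functional assay on a cell-free system (plasma, Homo sapiens), with a stated time of 3 min; a higher number here means a weaker inhibitor, a lower number a stronger inhibitor. Compound 1 `CC(C)(C)[C@@H](O)C(=O)N1C[C@@H]2C[C@@H]2[C@H]1C(=O)NCc1cc(Cl)ccc1-n1cnnn1` gives 570 nM. Compound 2 `COC(C)(C)[C@@H](O)C(=O)N1C[C@H]2C[C@H]2[C@H]1C(=O)NCc1cc(Cl)ccc1-n1cnnn1` gives 1000 nM. Although this is the higher of the two numbers, the values lie within the scatter of each other, so they do not separate compound 2 from compound 1.

Compound 3 `CC(C)(C)[C@@H](O)C(=O)N1C[C@H]2C[C@H]2[C@H]1C(=O)NCc1cc(Cl)ccc1-n1cnnn1` has not yet been measured. It differs from compound 2 in one place: methyl in place of methoxy on a saturated chain carbon bound to three saturated chain carbons. This puts methyl in place of methoxy on a saturated chain carbon bound to three saturated chain carbons, turning 1-methoxy-1-methylethyl into tert-butyl. Among the measured compounds shown here, no measured pair isolates this change, so its size in this assay has no direct precedent. The expectation rests only on compound 2 at 1000 nM and compound 1 at 570 nM. No step beyond the scatter is expected, with only a weak lean towards a lower number. The expected step is a 1.8-fold lower number from compound 2 to compound 3 (0.26 log units; within the scatter). For compound 3 the estimated value is 550 nM, with an expected range of 180 nM to 1600 nM.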

Compound 3, half-maximal inhibitory concentration: 1200 nM
The estimate for compound 3 lay 2.2-fold (0.34 log units) below the measured number; measured number inside the range.
By their numbers in this assay, from the lowest: compounds 1, 2 and 3 (each within the scatter of the next, the first and the last beyond it).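

In this assay, methyl in place of methoxy on a saturated chain carbon bound to three saturated chain carbons, turning 1-methoxy-1-methylethyl into tert-butyl, gives a 1.2-fold higher number from compound 2 to compound 3 (0.08 log units; within the scatter) and so does not separate the two groups at this position in this configuration. Among the compounds shown here, the series also gains its first step beyond the scatter, a modest one, with a 2.1-fold higher number from compound 1 to compound 3 (0.32 log units; beyond the scatter) as the only reading so far that separates any two compounds. This step can be assigned to configuration alone, because nothing else distinguishes the pair: the fact that compounds 1 and 3 differ only in the configuration as drawn.

As far as these compounds go, whether an amine, a carboxylic acid or a longer chain in place of methoxy on this carbon would give a step beyond the scatter remains open. It is also open whether the change from methoxy to methyl reads the same in the configuration of compound 1, since the compounds shown carry only tert-butyl in that configuration.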